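The source may hold more compounds than are shown below. What is called first, only, known or untested is meant among the compounds shown, and "the series" means these compounds.

Measured compounds:
- compound 1 `Cc1ccc(-c2cs/c(=N/NC(=O)CSc3nnnn3-c3ccccc3)n2-c2ccccc2)cc1`: 28.5%
- compound 2 `Cc1ccc(-c2cs/c(=N/NC(=O)CSc3nncn3C)n2-c2ccccc2)cc1`: 39.6%
- compound 3 `Cn1cnnc1SCC(=O)N/N=c1/scc(-c2ccc(C#N)cc2)n1-c1ccccc1`: 55.2%

In a functional assay on C6 cells (Rattus norvegicus) for cytotoxicity, read by MTT assay, with a stated time of 24 h, tested at 100 ug/mL (a higher number here means a weaker effect of the compound at the concentration tested, a lower number a stronger effect), compound 2 gives 39.6% and stands second highest of the three numbers, with compound 1 at 28.5% the nearest and compound 3 at 55.2% the furthest. Compound 4 `Cc1ccc(-c2cs/c(=N/NC(=O)CSc3nnc(C)s3)n2-c2ccccc2)cc1` is not yet measured; it differs from compound 2 in one place: 5-methyl-1,3,4-thiadiazol-2-yl in place of 4-methyl-4H-1,2,4-triazol-3-yl on a sulfur. Of the measured steps only a number 11.1 percentage points higher from compound 1 to compound 2 (beyond the scatter) concerns the ring on that sulfur; a number 15.6 percentage points higher from compound 2 to compound 3 (beyond the scatter) concerns a cyano in place of methyl on an aromatic carbon and does not bear on this change. Within the data shown here, with one modest ring swap on that sulfur as the sole precedent, and no thiadiazole among the measured compounds, the direction is open; a step within or just beyond the scatter is expected, a number 2.4 percentage points higher from compound 2 to compound 4 (within the scatter). Compound 4 is therefore expected to give about 42%, between 28% and 58%.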

Compound 4, a percentage reported as activity, at one concentration (the size of the read-out at that concentration, not a potency): 31.5%
Beside the measured number, compound 4's estimate is 10.5 percentage points above it; the range from low to high includes it.
By their numbers in this assay, from the lowest: compounds 1, 4 and 2 (each within the scatter of the next, the first and the last beyond it); then compound 3.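

In this assay, 5-methyl-1,3,4-thiadiazol-2-yl on the sulfur gives a number 8.1 percentage points lower from compound 2 to compound 4 (within the scatter), and in place of 1-phenyl-1H-tetrazol-5-yl it gives a number 3 percentage points higher from compound 1 to compound 4 (within the scatter). Compound 4 thus lies within the scatter of both compounds, so this third ring does not separate from either, although the two earlier rings differ beyond the scatter. As far as these compounds go, it remains open whether an open chain ending in a carboxylic acid or an amine on that sulfur would hold this level, and whether cyano in place of methyl would shift compound 4 as it shifted compound 2. Nothing available explains these numbers.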